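The source may hold more compounds than are shown below. What is called first, only, known or untested is meant among the compounds shown, and "the series" means these compounds.

Among the compounds with values here, compound 1 `CCOC(=O)C1=C(C)N/C(=C/c2cc(C)n(-c3ccc(Cl)cc3)c2C)C1=O` is the only compound with a definite number in a physicochemical assay for solubility, read by nephelometry, measured as kinetic solubility, at pH 2.0 (on this read-out higher numbers stand for higher solubility and lower numbers for lower solubility), where compound 1 gives 1.6 ug/mL. Compound 2 `CCOC(=O)C1=C(C)N/C(=C/c2cc(C)n(-c3cccnc3)c2C)C1=O` reaches only a limit of this assay, namely > 50 ug/mL. Within the data shown here, the step of an at least 31-fold higher number from compound 1 to compound 2 (1.49 log units; beyond the scatter) is the sole measured change, and its size is bounded by the limit of > 50 ug/mL in this assay, at which 1 of the 2 values shown sits. Compound 3 `CCOC(=O)C1=C(C)N/C(=C/c2cc(C)n(-c3ccc(CN4CCCCC4)cc3)c2C)C1=O` differs from compound 1 by (piperidin-1-yl)methyl in place of chloro on an aromatic carbon. That change is not the one that was measured, so the measured step offers only loose guidance; a rise in this assay is nonetheless expected, estimated as a 22-fold higher number from compound 1 to compound 3 (1.34 log units; beyond the scatter). Compound 3 is estimated at 35 ug/mL, with a range from 8 ug/mL to 50 ug/mL.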

Compound 3, solubility: 50 ug/mL
Beside the measured number, compound 3's estimate is 1.4-fold (0.15 log units) below it, within the range that was stated.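

Compound 1 and compound 3 share the ring on the nitrogen and differ only in the group on its aromatic carbon, and in this assay this single change gives a 31-fold higher number from compound 1 to compound 3 (1.49 log units; beyond the scatter). A large step here therefore does not require replacing that ring, and this step rests on two definite numbers. Compound 2, in contrast, stands at a limit: the limit of > 50 ug/mL in this assay, at which 1 of the 3 values shown sits.

The compounds shown leave open whether a smaller amine such as dimethylaminomethyl, a morpholin-4-ylmethyl group or a carboxylic acid on this carbon would give a similar step. They also leave open how (piperidin-1-yl)methyl would read elsewhere on the ring.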